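A few compounds are considered here, and "the series" means these few. Any claim that something is new, unique, unknown or untested is made for them only; others in the source may bear on it.

Of the compounds shown here, three on a shared core have been read so far in a functional assay on HeLa cells (Homo sapiens) for antiproliferative activity, read by XTT assay, with a stated time of 72 h (on this read-out higher numbers stand for weaker inhibition and lower numbers for stronger inhibition), and all give clear numbers. Compound 1 (`C=C(C)CCC[C@]1(C)C2=CCC[C@](C)(C[C@@H](OC(C)=O)C3=CC(=O)OC3O)[C@H]2CC[C@H]1C`) gives 3500 nM here, compound 2 (`C=C(C)CCC[C@]1(C)C2=CCC[C@](C)(C[C@@H](O)C3=CC(=O)OC3O)[C@H]2CC[C@H]1C`) gives 2600 nM here and compound 3 (`C=C(C)CC[C@]1(C)C2=CCC[C@](C)(C[C@@H](O)C3=CC(=O)OC3O)[C@H]2CC[C@H]1C`) gives 5400 nM here. Compound 2 sits with compound 1 at the low end of these numbers: the step of a 1.3-fold lower number from compound 1 to compound 2 (0.13 log units; within the scatter) lies within the scatter, while the step of a 2.1-fold higher number from compound 2 to compound 3 (0.32 log units; beyond the scatter) is modest and lies beyond it.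

Compound 4 (`C=C(C)CCC[C@]1(C)C2=CCC[C@](C)(C[C@@H](O)c3ccoc3)[C@H]2CC[C@H]1C`) changes a different place, and a group of 5 heavy atoms (4 carbon, 1 oxygen; one five-membered aromatic ring with 1 hetero atom) in place of a group of 7 heavy atoms (4 carbon, 3 oxygen; one five-membered non-aromatic ring with 1 hetero atom), on a saturated chain carbon bound to an oxygen on a saturated carbon and a saturated chain carbon is the whole change. Neither measured step touches that place, since all three measured compounds keep the group that leaves, so the data hold no direct measure of this swap. A higher number is still expected, as a judgement only: the step of a 2.1-fold higher number from compound 2 to compound 3 (0.32 log units; beyond the scatter) shows that a change elsewhere already moved the number beyond the scatter. The expected step is a 3.5-fold higher number from compound 2 to compound 4 (0.54 log units; beyond the scatter) and it stays a rough estimate. For compound 4 the estimate is 9000 nM with an expected range from 3000 nM to 30000 nM overall.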

Compound 4, half-maximal inhibitory concentration: 59400 nM
Beside the measured number, compound 4's estimate is 6.6-fold (0.82 log units) below it; measured number above the stated range.
By their numbers in this assay, from the lowest: compounds 2, 1 and 3 (each within the scatter of the next, the first and the last beyond it); then compound 4.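

In this assay, replacing the non-aromatic five-membered ring group with furan-3-yl on the saturated chain carbon gives a 23-fold higher number from compound 2 to compound 4 (1.36 log units; beyond the scatter), so this position responds strongly to this change. Going by these compounds alone, the earlier steps in the other two places were far smaller: a 1.3-fold lower number from compound 1 to compound 2 (0.13 log units; within the scatter) lies within the scatter, and a 2.1-fold higher number from compound 2 to compound 3 (0.32 log units; beyond the scatter) is only modest, which makes this the largest step so far. No supporting measurement bears on why the number rises so sharply at this position.

With furan-3-yl as the only replacement shown, the compounds leave open which features of the departing group matter for the number. Also open, on these data alone, is whether another group at this place, such as a carboxylic acid or an amine, would give a number nearer that of the parent group.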